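A few compounds are considered here, and "the series" means these few. Any claim that something is new, unique, unknown or untested is made for them only; others in the source may bear on it.

Measured compounds:
- Compound 1, `CCN(Cc1cc[nH]n1)C(=O)COc1ccc(C)cc1`: "not active" (no number reported)
- Compound 2, `Cc1ccc(OCC(=O)N(Cc2cccs2)c2ncco2)cc1`: 0.3 nM
- Compound 3, `CCN(Cc1cccs1)C(=O)c1cc2cc(C)ccc2s1`: 1600 nM

Three compounds were tested in an assay on HEK293 cells for agonist activity at transient receptor potential cation channel subfamily M member 8 (Homo sapiens), read by fluorescence and calcium flux, with a stated time of 15 min; a lower number here means that less compound is needed, a higher number that more compound is needed for the effect. Compound 2 gives 0.3 nM in this assay, and compound 3 gives 1600 nM. For compound 1 the result in this assay is recorded only as "not active" (no number reported), so no single number marks where it stands; it can only be said that it did not show the effect under the conditions of the test, while compound 2 and compound 3 did.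

The piece follows one step from compound 1 to a compound not yet tested, compound 4, `CCN(Cc1cc[nH]c1)C(=O)COc1ccc(C)cc1`. The two structures differ in one place: 1H-pyrrol-3-yl in place of 1H-pyrazol-3-yl on a saturated chain carbon bound to an amide-type nitrogen. Everything else in the molecule is kept as in compound 1.

For the measured compounds named here, no measured pair shows this particular change, so its size in this assay is not known from the data. Since compound 1 gave no effect at all, the expectation is that compound 4 will behave much the same, with no change beyond the usual scatter, and that a limit rather than a number is the more likely outcome. If a number does appear, compound 4 is expected to give 10000 nM in this assay, with a range from 1000 nM to 100000 nM.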

Compound 4, half-maximal effective concentration: 21800 nM
For compound 4 the middle estimate is 2.2-fold (0.34 log units) below the measured one; low and high end bracket the measured number.
By their numbers in this assay, from the lowest: compound 2; then compound 3; then compound 4.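

For the compounds shown here, compound 1 has no number, so the step from compound 1 to compound 4 cannot be given a size, and no other pair here differs in one place. From the compounds shown here alone, how far 1H-pyrrol-3-yl in place of 1H-pyrazol-3-yl shifts the result therefore stays open. Nothing shown offers an explanation for the value of compound 4.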